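This account rests on a few compounds, and the source may have more. Where it says the series, first, only, none or still open, it means among the compounds named here.

In a functional assay on MCF7 cells (Homo sapiens) for antiproliferative activity, read by sulforhodamine B assay, with a stated time of 48 h (on this read-out higher numbers stand for weaker inhibition of growth and lower numbers for stronger inhibition of growth), three compounds have been measured. Compound 1 `COc1ccc(Cn2cc(CNC(=O)c3cn(-c4ccccc4)nc3-c3ccccc3)nn2)cc1OC` gives 12600 nM. Compound 2 `COc1ccc(Cn2cc(CNC(=O)c3cn(-c4ccccc4)nc3-c3ccc(Cl)cc3)nn2)cc1OC` reaches only a limit of the assay, recorded as > 100000 nM. Compound 3 `COc1ccc(Cn2cc(CNC(=O)c3cn(-c4ccccc4)nc3-c3ccc(OC)cc3)nn2)cc1` gives 22900 nM. Within the data shown here, the one step between compounds that differ in a single place is an at least 7.9-fold higher number from compound 1 to compound 2 (0.89 log units; beyond the scatter), a chloro in place of hydrogen on an aromatic carbon. Compound 2 sits at the limit of > 100000 nM in this assay, at which 1 of the 3 values shown sits, so this step is known only as a smallest possible size. Among the two numbers shown, compound 3 stands highest, with compound 1 nearest at a gap within the usual scatter, so those two cannot be ranked against each other.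

Compound 4 `COc1ccc(-c2nn(-c3ccccc3)cc2C(=O)NCc2cn(Cc3ccc(OC)c(OC)c3)nn2)cc1` differs from compound 3 in one place: methoxy in place of hydrogen on an aromatic carbon. Among the measured compounds shown here, no measured step adds a methoxy group, and the only measured step, an at least 7.9-fold higher number from compound 1 to compound 2 (0.89 log units; beyond the scatter), concerns a different group at a different place on the same aromatic ring, so it gives little guidance. A change within the scatter is therefore expected. The estimate for compound 4 is 30000 nM, within a range from 10000 nM to 100000 nM, which means an expected step of a 1.3-fold higher number from compound 3 to compound 4 (0.12 log units; within the scatter).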

Compound 4, concentration for 50% growth inhibition: > 100000 nM
Compound 4: a limit, no number (the forecaster's own chance of this, stated with the estimate: 25%); middle value at least 3.3-fold (0.52 log units) away from the limit.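

In this assay, adding one methoxy group to the 4-methoxybenzyl group of compound 3, which turns it into 3,4-dimethoxybenzyl, is not a neutral change: the result is an at least 4.3-fold higher number from compound 3 to compound 4 (0.64 log units; beyond the scatter). Among these compounds, compound 4 can also be reached from compound 1 by placing a methoxy on the aromatic carbon where compound 2 carries chloro, and this gives an at least 7.9-fold higher number from compound 1 to compound 4 (0.89 log units; beyond the scatter), so with the 3,4-dimethoxybenzyl group kept, chloro is no longer the only group at that carbon seen to go with a loss of growth inhibition. Both steps are known only as smallest possible sizes, and the step between compound 2 and compound 4 cannot be read, because each of the two compounds stands at a limit rather than a number: the limit of > 100000 nM in this assay, at which 2 of the 4 values shown sit.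

On these data alone, how much weaker compound 4 really is remains open, since its value is a limit and not a number. As far as these compounds go, it is also open whether a fluoro, a hydroxyl or an amine on either of these two rings would keep a readable value, or would also end at the limit.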